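This account rests on a few compounds, and the source may have more. Where it says the series, first, only, none or still open, it means among the compounds named here.

Three compounds share one core and differ only in the group attached to a saturated chain carbon, two bonds along the chain from an amide-type nitrogen and a carbonyl carbon. In a functional assay on the whole organism (Tail, strain ICR) with Mus musculus as the target, in the tail flick test, with a stated time of 120 min, at a dose of 25 umol/kg by the oral route (on this read-out higher numbers stand for a stronger effect at the one dose given and lower numbers for a weaker effect), compound 1 `C[C@H](NC(=O)CN(c1nc(Cl)nc2[nH]cnc12)C1CC1)C(=O)OCc1ccccc1` gives 36.1%, compound 2 `CSCC[C@H](NC(=O)CN(c1nc(Cl)nc2[nH]cnc12)C1CC1)C(=O)OCc1ccccc1` gives 31.6%, and compound 3 `CC(C)C[C@H](NC(=O)CN(c1nc(Cl)nc2[nH]cnc12)C1CC1)C(=O)OCc1ccccc1` gives 8.58%. Compound 3 is thus the lowest of the three: its nearest neighbour is compound 2, and the step of a number 23 percentage points lower from compound 2 to compound 3 (beyond the scatter) lies beyond the scatter, while the step of a number 27.5 percentage points lower from compound 1 to compound 3 (beyond the scatter) is wider still. Compounds 1 and 2 sit within the scatter of each other, as the step of a number 4.5 percentage points lower from compound 1 to compound 2 (within the scatter) shows.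

Compound 4 `NC(=O)C[C@H](NC(=O)CN(c1nc(Cl)nc2[nH]cnc12)C1CC1)C(=O)OCc1ccccc1` takes the next step from compound 3: carbamoyl in place of isopropyl on a saturated chain carbon, two bonds along the chain from an amide-type nitrogen and a carbonyl carbon. Going by the values given here, no measured step introduces a carbamoyl group, so there is no direct precedent for it. What the data do show is that the isopropyl group in compound 3 coincides with the lowest value, and that compounds without it, compound 1 and compound 2, lie well above it. On that basis, a rise in this assay is expected for compound 4, with real uncertainty about its size, and the step of a number 16.4 percentage points higher from compound 3 to compound 4 (beyond the scatter) is an estimate only. Compound 4 is therefore expected to give about 25%, somewhere between 5% and 45%.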

Compound 4, a percentage reported as activity, at one dose (the size of the read-out at that dose, not a potency): 15.1%
Compound 4: the middle estimate sits 9.9 percentage points above what was measured; low and high end bracket the measured number.
By their numbers in this assay, from the lowest: compounds 3 and 4 (each within the scatter of the next); then compounds 2 and 1 (each within the scatter of the next).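

In this assay the change to carbamoyl gives a number 6.5 percentage points higher from compound 3 to compound 4 (within the scatter) and so does not clearly separate the two groups, even though carbamoyl brings a nitrogen, an oxygen, a hydrogen-bond donor and a hydrogen-bond acceptor where isopropyl has carbon alone. The low end of this small series is therefore not confined to isopropyl, since carbamoyl also falls short of the other two groups at this position, with a number 16.5 percentage points lower from compound 2 to compound 4 (beyond the scatter) and a number 21 percentage points lower from compound 1 to compound 4 (beyond the scatter) as the steps that show it. Nothing measured here explains why hydrogen and (methylsulfanyl)methyl go with the higher numbers while two such different groups go with the lower numbers.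

As far as these compounds go, it remains open whether an amine, a carboxylic acid or a longer carbon chain on this saturated chain carbon would read with compounds 1 and 2 or with compounds 3 and 4. Going by these compounds alone, each compound also has only one reading, at a single dose and a single time, so it remains open whether the same grouping would appear at other doses or times.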